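The source may report more compounds than this note shows. Statements on the series, on what has been measured and on what is new or still open speak of the compounds shown alone.

Two ureas have been measured in an ADME assay on the whole organism with Oryza sativa as the target, tested at 0.1 uM; a higher number here means a weaker effect of the compound at the concentration tested, a lower number a stronger effect. Compound 1, `CCc1ccccc1NC(=O)N[C@@H](C)c1ccccc1`, gives 100% in this assay. Compound 2, `C[C@@H](NC(=O)Nc1ccccc1Cl)c1ccccc1`, gives 101% in this assay. These two readings sit within the usual scatter of each other, so compound 2 and compound 1 cannot be told apart on these numbers, and both show essentially no effect at the concentration tested.

The next compound, compound 3, `C[C@H](NC(=O)Nc1ccccc1Cl)c1ccccc1`, is the mirror-image partner of compound 2: the two compounds have the same atoms and bonds and differ only in configuration as drawn: 1 of 1 stereo elements differ; a stereocentre at a saturated chain carbon is drawn R in compound 2 and S in compound 3. Going by the values given here, no step between two measured compounds is available to show how a change of this kind moves the reading, so the expectation rests on compound 2 alone. Since compound 2 already shows no effect, compound 3 is expected to behave alike, with a step of a number 2 percentage points lower from compound 2 to compound 3 (within the scatter) that is no larger than the scatter. For compound 3 the estimate in this assay is 99%, within a range from 88% to 108%.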

Compound 3, a percentage reported as activity, at one concentration (the size of the read-out at that concentration, not a potency): 99%
Compound 3: the middle estimate sits on the measured number at the digits printed, and the stated range covers the measured number.
By their numbers in this assay, from the lowest: compounds 3, 1 and 2 (each within the scatter of the next).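

Turning the stereocentre at the saturated chain carbon from R to S gives a number 2 percentage points lower from compound 2 to compound 3 (within the scatter) in this assay, so this assay does not tell this mirror-image pair apart at the concentration tested. Going by these compounds alone, this reading can be tied to configuration alone, because nothing else changes: the fact that compounds 2 and 3 differ only in the configuration as drawn The first step at the aromatic carbon, chloro in place of ethyl, gives a number 1 percentage points lower from compound 1 to compound 3 (within the scatter), so this swap also leaves the reading within the scatter.

All of these readings stay close to no effect, which leaves open whether configuration would matter in a compound with a clear effect in this assay. On these data alone, it is also open whether a different group on that aromatic carbon, such as an amine, a carboxylic acid or a longer chain, would move the reading beyond the scatter.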